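The source may hold more compounds than are shown below. What is called first, only, known or untested is meant among the compounds shown, and "the series" means these compounds.

In a functional assay on U-87MG ATCC cells for antiproliferative activity against U-87 MG (Homo sapiens), read by MTT assay, with a stated time of 48 h (a higher number here means a weaker inhibitor, a lower number a stronger inhibitor), compound 1 (`COc1ccc(-c2nc(SCC(=O)c3sc(-c4ccccc4)nc3C)nc(N)c2C#N)cc1`) gives 14000 nM. Compound 3 (`COc1ccc(-c2nc(C)c(C(=O)CSc3nc(-c4ccc(OC)cc4)c(C#N)c(=O)[nH]3)s2)cc1`) gives 25300 nM, which lies within the scatter of compound 1. Compound 2 (`COc1ccc(-c2nc(SCC(=O)c3sc(-c4ccccc4)nc3C)[nH]c(=O)c2C#N)cc1`) gives 48400 nM, a higher number than that of compound 1 and beyond the scatter. Compound 1 therefore stands at the low end of these three numbers, though it shares that end with compound 3.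

The next compound, compound 4 (`Cc1nc(-c2ccccc2)sc1C(=O)CSc1nc(N)c(C#N)c(-c2ccc(Cl)cc2)n1`), departs from compound 1 at a single place: chloro in place of methoxy on an aromatic carbon. This is chloro in place of methoxy on an aromatic carbon, a change from 4-methoxyphenyl to 4-chlorophenyl, para to a large group.

For the measured compounds named here, no measured step makes this exchange. Going by the values given here, the only step between compounds differing in one place is a 1.9-fold lower number from compound 2 to compound 3 (0.28 log units; within the scatter), for methoxy in place of hydrogen on an aromatic carbon, and it lies within the scatter. That step sits at another place in the structure, so it bears on the change only indirectly and sets no direction. Among the compounds with values here, with only that small step as a guide, no shift beyond the scatter is expected in this assay. The expected step is a 1.1-fold higher number from compound 1 to compound 4 (0.03 log units; within the scatter), which is within the scatter. Compound 4 is estimated at 15000 nM, with an expected range from 5500 nM to 40000 nM.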

Compound 4, half-maximal inhibitory concentration: 10800 nM
Compound 4: middle estimate off by 1.4-fold (0.14 log units), on the high side, and the stated range covers the measured number.
By their numbers in this assay, from the lowest: compounds 4, 1, 3 and 2 (each within the scatter of the next, the first and the last beyond it).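

For the compounds shown here, at the 4-methoxyphenyl position, on an aromatic carbon of a six-membered aromatic ring of carbon only, this assay gives its first direct reading of a change, since the only earlier step lay elsewhere in the structure. Replacing methoxy with chloro gives a 1.3-fold lower number from compound 1 to compound 4 (0.11 log units; within the scatter), so this exchange, which also removes the oxygen and its hydrogen-bond acceptor from this place, does not separate the two compounds in this assay, and the methoxy oxygen is not shown to matter here. The step sets no direction for the position, and no measurement at hand explains the result.

What the compounds shown leave open is whether a hydroxyl, an amine, a carboxylic acid or a longer chain such as ethoxy at this place would also stay within the scatter of compound 1, or would at last move the number beyond it. They also leave open whether chloro in place of methoxy reads the same on the core of compound 2, which carries a ring carbonyl and the amide hydrogen where compound 1 carries its amino group.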